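The source may hold more compounds than are shown below. What is called first, only, known or untested is meant among the compounds shown, and "the series" means these compounds.

Measured compounds in a functional assay on MCF7 cells (Homo sapiens) for inhibition, read by sulforhodamine B assay, with a stated time of 72 h; on this read-out lower numbers stand for stronger inhibition and higher numbers for weaker inhibition:

compound 1, `COc1ccc2cc(C(C)c3nnc4n3N=C(c3ccc([N+](=O)[O-])cc3)CS4)ccc2c1`, gives 18800 nM
compound 2, `COc1ccc2cc(C(C)c3nnc4n3N=C(c3ccc(F)cc3)CS4)ccc2c1`, gives 15800 nM

Among the compounds with values here, compound 2 gives the lowest of the two numbers so far, but its only neighbour is compound 1, and the step of a 1.2-fold lower number from compound 1 to compound 2 (0.08 log units; within the scatter) lies within the scatter, so the two are not distinguished by this assay.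

Compound 3, `COc1ccc2cc(C(C)c3nnc4n3N=C(c3ccc(Cl)cc3)CS4)ccc2c1`, is not yet measured. It differs from compound 2 by chloro in place of fluoro on an aromatic carbon.

Within the data shown here, no measured step bears directly on this change: the single recorded step swaps nitro for fluoro at the same aromatic carbon, and that step, a 1.2-fold lower number from compound 1 to compound 2 (0.08 log units; within the scatter), stayed within the scatter. Nothing in the two measured compounds therefore points to a shift beyond the scatter for a further swap of one halogen for another at that position. The expectation for a 1.2-fold lower number from compound 2 to compound 3 (0.08 log units; within the scatter) is a small step, if any, with no reliable direction.

Compound 3 is thus estimated at 13000 nM, with a range from 6000 nM to 28000 nM.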

Compound 3, half-maximal inhibitory concentration: 10100 nM
Compound 3: the middle estimate sits 1.3-fold (0.11 log units) above what was measured; the range from low to high includes it.
By their numbers in this assay, from the lowest: compounds 3, 2 and 1 (each within the scatter of the next).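

In this assay, within the data shown here, the first exchange of one halogen for another on this aromatic carbon, 4-fluorophenyl to 4-chlorophenyl, gives a 1.6-fold lower number from compound 2 to compound 3 (0.19 log units; within the scatter), and the exchange of nitro for chloro at the same carbon gives a 1.9-fold lower number from compound 1 to compound 3 (0.27 log units; within the scatter). With these steps, all three pairs among the nitro, fluoro and chloro compounds are printed as within the scatter, so this assay separates none of the three substituents at this place, which stands para to a large group, and the earlier single step could not show this for a second halogen or for the full set of three. Nothing available bears on the reason for these numbers, so the small steps carry no explanation beyond their size.

Whether an amine or a carboxylic acid on this same aromatic carbon would give a step beyond the scatter remains open, since the three substituents shown span only nitro, fluoro and chloro. Also open, on these data alone, is whether a longer chain elsewhere on the shared core would move the number further than any exchange at this carbon has done.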